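A Dimethylamino-to-Amino Swap Repeated on a Longer Chain

The source may hold more compounds than are shown below. What is called first, only, known or untested is meant among the compounds shown, and "the series" means these compounds.

Compound 1 is `CCCCCCC(CCO)n1cnc2c(N(C)C)ncnc21`. In a functional assay on HCT-116 cells (Homo sapiens) for antiproliferative activity, read by MTT assay, with a stated time of 48 h (a lower number here means a stronger inhibitor, a higher number a weaker inhibitor), compound 1 gives only a limit of the assay, > 50000 nM. Compound 2 is `CCCCCCC(CCO)n1cnc2c(N)ncnc21`, and it differs from compound 1 by amino in place of dimethylamino on an aromatic carbon. In this assay compound 2 likewise gives only a limit, > 50000 nM. The step that the two limits leave unreadable from compound 1 to compound 2 therefore cannot be sized. Compound 3 is `CCCCCCCC(CCO)n1cnc2c(N(C)C)ncnc21`; its core differs from the core of compound 1 by methyl in place of hydrogen on a saturated chain carbon, seven bonds along the chain from an aromatic nitrogen. In this assay compound 3 also gives only a limit, > 50000 nM, so the step that the two limits leave unreadable from compound 1 to compound 3 is equally unreadable. The one point on which all three measured compounds agree is the limit of > 50000 nM in this assay, at which 3 of the 3 values shown sit.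

Compound 4, which has not been measured, is `CCCCCCCC(CCO)n1cnc2c(N)ncnc21`. It differs from compound 3 by amino in place of dimethylamino on an aromatic carbon. The surroundings of this change read word for word as they do for the change from compound 1 to compound 2, so it is the same change, carried out on the core of compound 3 instead of the core of compound 1. Because the limit of > 50000 nM in this assay, at which 3 of the 3 values shown sit, is all that the measured compounds show, no direction can be read from them, and the expectation for compound 4 rests on that limit alone. For compound 4 the expected step is a number no higher from compound 3 to compound 4 (the limit leaves the size open). The estimate for compound 4 in this assay is 50000 nM, and the most likely outcome is that the assay once more reports only a limit.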

Compound 4, half-maximal inhibitory concentration: > 50000 nM
Compound 4 ended at the assay's limit; the forecaster's own chance of this, stated with the estimate: 85%; the middle value lies on the limit itself.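

In this assay, among the compounds shown here, compound 4 gives only a limit, so its steps from compound 3 and from compound 2 cannot be read, and no new step emerges. All the compounds shown share one result: the limit of > 50000 nM in this assay, at which 4 of the 4 values shown sit.

The compounds shown leave open whether swapping dimethylamino for amino, or adding the methyl on the chain, changes the inhibition in this assay at all.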